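The compounds below may be only part of what the source reports. "The series", "measured", "known", "first", "only" and "open" are said of these compounds alone.

Working notes on the series

The three measured compounds share one core. Compound 2 `COc1cc(-c2cc(/C=C/C(=O)c3ccc(N)cc3)[nH]n2)cc(OC)c1OC` gives 1010 nM in a functional assay on MDA-MB-468 cells (Homo sapiens) for inhibition, read by sulforhodamine B assay, with a stated time of 48 h; a lower number here means a stronger inhibitor of growth, a higher number a weaker inhibitor of growth. Among the three numbers it stands second highest; compound 3 `COc1ccc(C(=O)/C=C/c2cc(-c3cc(OC)c(OC)c(OC)c3)n[nH]2)cc1` is nearest, giving 1290 nM, and the step of a 1.3-fold higher number from compound 2 to compound 3 (0.11 log units; within the scatter) covers that pair. Going by the values given here, compound 1 `COc1ccc(-c2cc(/C=C/C(=O)c3ccc(N)cc3)[nH]n2)cc1` gives 430 nM and lies furthest from compound 2; no step is computed for that pair, and their two values differ beyond the scatter, compound 1 giving the lower number.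

Compound 4 `COc1ccc(-c2cc(/C=C/C(=O)c3ccc(N)cc3)[nH]n2)cc1OC` is not yet measured. It differs from compound 2 by hydrogen in place of methoxy on an aromatic carbon, the hydrogen entering on an aromatic carbon of a six-membered aromatic ring of carbon only, ortho to a methoxy group, meta to a large group and meta to a methoxy group. Among the compounds with values here, the only computed step, the methoxy-for-amino exchange from compound 2 to compound 3, sits on the amino-bearing part of the molecule and was within the scatter, so it bears only weakly on a methoxy removal. The values of compound 1 and compound 2 suggest that fewer methoxy groups on this ring go with a lower number, though with only two points that is no pattern. The expected step is modest, a 1.6-fold lower number from compound 2 to compound 4 (0.19 log units; within the scatter), possibly within the scatter. Compound 4 is estimated at 650 nM, with a range from 300 nM to 1400 nM.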

Compound 4, concentration for 50% growth inhibition: 1550 nM
For compound 4 the middle estimate is 2.4-fold (0.38 log units) below the measured one; the measured number lies above the stated range.
By their numbers in this assay, from the lowest: compound 1; then compounds 2, 3 and 4 (each within the scatter of the next).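

In this assay, going by these compounds alone, the methoxy on the aromatic carbon ortho to a methoxy group and meta to a large group is the first change at this position to be read from both sides: taking it away gives a 1.5-fold higher number from compound 2 to compound 4 (0.19 log units; within the scatter), while adding it to the core of compound 1 gives a 3.6-fold higher number from compound 1 to compound 4 (0.56 log units; beyond the scatter), a step that stands clear of the scatter. The effect of a methoxy at this carbon therefore depends on the rest of the ring, since the same exchange is readable as a real loss of growth inhibition when the other meta position carries hydrogen and is not separable from the scatter when that position carries a methoxy, and compounds 1, 2 and 4 alone cannot show whether this holds for other groups. Nothing available explains this dependence on the rest of the ring.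

As far as these compounds go, whether the step follows from the oxygen or from the methyl of the methoxy stays open, and a hydroxy group, an ethoxy group or a fluorine atom on this carbon would bear on that. Also open, from the compounds shown here alone, is whether replacing the amino group with methoxy, read so far only on the compound 2 ring pattern as a 1.3-fold higher number from compound 2 to compound 3 (0.11 log units; within the scatter), behaves the same way on the core of compound 1.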